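Swapping the indazole substituent on the weakest compound

The source may hold more compounds than are shown below. What is called first, only, known or untested is meant among the compounds shown, and "the series" means these compounds.

The series is followed in a functional assay on MCF7 cells (Homo sapiens) for cytotoxicity, read by CellTiter-Glo, with a stated time of 5 days; a higher number here means a weaker inhibitor, a lower number a stronger inhibitor. Within the data shown here, compound 1 `CC(C)/C(=C(/c1ccc(/C=C/C(=O)O)cc1)c1ccc2[nH]ncc2c1)c1ccccc1` gives 4 nM in this assay, and compound 2 `O=C(O)/C=C/c1ccc(/C(=C(\c2ccccc2)C2CCC2)c2ccc3[nH]ncc3c2)cc1` gives 1.4 nM; the only step between them, a 2.9-fold lower number from compound 1 to compound 2 (0.46 log units; beyond the scatter), concerns the chain carbon and not the indazole. Compound 3 `CC/C(=C(/c1ccc(/C=C/C(=O)O)cc1)c1cc2cn[nH]c2cc1C)c1ccccc1` stands apart: it gives 468 nM in this assay, the highest of the three numbers, with the values of compound 1 and compound 2 both far lower and both beyond the scatter.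

Compound 4 `CC/C(=C(/c1ccc(/C=C/C(=O)O)cc1)c1ccc2[nH]nc(Cl)c2c1)c1ccccc1` is formed from compound 3 by 3-chloro-1H-indazol-5-yl in place of 6-methyl-1H-indazol-5-yl on a double-bonded chain carbon bound to an aromatic carbon and a double-bonded chain carbon. Among the measured compounds shown here, no measured step changes the indazole substituent, so none bears directly on this change; the one measured step, at another position, was modest. What can be said is that compound 1 and compound 2, which carry an indazole without the methyl, sit far below compound 3, while compound 4 keeps the ethyl of compound 3 and adds a chlorine in a new position. The author therefore expects compound 4 to give a number well below that of compound 3, with wide uncertainty, estimated at 20 nM (range 3 nM to 150 nM). That estimate means a step of a 23-fold lower number from compound 3 to compound 4 (1.37 log units; beyond the scatter) in this assay, an expectation rather than a measurement.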

Compound 4, half-maximal inhibitory concentration: 284 nM
Compound 4: the middle estimate sits 14-fold (1.15 log units) below what was measured, and the stated range ends below it.
By their numbers in this assay, from the lowest: compound 2; then compound 1; then compounds 4 and 3 (each within the scatter of the next).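

Among these compounds, the step in this assay is a 1.6-fold lower number from compound 3 to compound 4 (0.22 log units; within the scatter) and so gives the first measured reading of a change in the indazole substituent: with the ethyl chain kept, 3-chloro-1H-indazol-5-yl and 6-methyl-1H-indazol-5-yl cannot be told apart on this double-bonded chain carbon. Exchanging one substituted indazole for the other, with the new group standing in a different place on that indazole, therefore does not separate this pair in this read-out. No measurement offered here accounts for this result.

The compounds shown leave open how an ethyl compound carrying unsubstituted 1H-indazol-5-yl would read, and so whether the chain or the substituent on the indazole accounts for the distance between compound 3 and compound 1, which differ in both places. They also leave open whether another group in the place of the chlorine on the 1H-indazol-5-yl, such as a fluorine, a nitrile or an amine, would read any differently with the ethyl chain kept.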